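The source may report more compounds than this note shows. Statements on the series, on what has been measured and on what is new or still open speak of the compounds shown alone.

Measured in an ADME assay for permeability, using PAMPA, at pH 7.4; a lower number here means that the compound crosses the layer more slowly, a higher number that the compound crosses the layer faster:
- compound 1 `CC(C)N(C)[C@@H]1CC[C@H](N2CC[C@H](NC(=O)c3cccc(C(F)(F)F)c3)C2=O)[C@H](NS(C)(=O)=O)C1`: 593 nm/s
- compound 2 `CC(C)N(C)[C@@H]1CC[C@H](N2CC[C@H](Nc3ncnc4ccc(C(F)(F)F)cc34)C2=O)[C@H](CS(C)(=O)=O)C1`: 14 nm/s

Compound 2 stands lowest of the two at 14 nm/s, beyond the scatter from compound 1. Compound 3 `CC(C)N(C)[C@@H]1CC[C@H](N2CC[C@H](Nc3ncnc4ccc(C(F)(F)F)cc34)C2=O)[C@H](NS(C)(=O)=O)C1` has methanesulfonamido in place of (methylsulfonyl)methyl on a saturated ring carbon of compound 2 (methanesulfonamido in place of (methylsulfonyl)methyl on a saturated ring carbon). Among the compounds with values here, no measured pair shows this change alone. Within the data shown here, the only guide is compound 1, which also carries methanesulfonamido and gives 593 nm/s. A rise in this assay is therefore expected, estimated as a 3.6-fold higher number from compound 2 to compound 3 (0.55 log units; beyond the scatter), though a step within the scatter remains possible. For compound 3 the estimated value is 50 nm/s, with an expected range of 10 nm/s to 300 nm/s.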

Compound 3, apparent permeability: 394 nm/s
The estimate for compound 3 lay 7.9-fold (0.90 log units) below the measured number, and the stated range ends below it.
By their numbers in this assay, from the lowest: compound 2; then compounds 3 and 1 (each within the scatter of the next).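

In this assay, methanesulfonamido in place of (methylsulfonyl)methyl on a saturated ring carbon gives a 28-fold higher number from compound 2 to compound 3 (1.45 log units; beyond the scatter), so this one change on an otherwise unchanged structure moves the read-out well beyond the scatter. The entering group brings a nitrogen and a hydrogen-bond donor, while the heavy-atom count stays the same. Nothing measured here gives a reason for the step.

As far as these compounds go, it remains open whether an acetamido group or a methanesulfonyl(methyl)amino group at this carbon would give a similar number. From the compounds shown here alone, the size of this step on the core of compound 1 also remains open.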